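Weak Sulfatase Inhibition Across Three Aryl Sulfamate Amides

A few compounds are considered here, and "the series" means these few. Any claim that something is new, unique, unknown or untested is made for them only; others in the source may bear on it.

Measured compounds:
Compound 1 `CCN(Cc1ccccn1)c1cccc(C(=O)N2CCc3ccc(OS(N)(=O)=O)cc3C2)c1`: 6.5%
Compound 2 `NS(=O)(=O)Oc1ccc2c(c1)CN(C(=O)c1cccc(N3CCN(c4ncccn4)CC3)c1)CC2`: 1.6%
Compound 3 `NS(=O)(=O)Oc1ccc2c(c1)CN(C(=O)c1ccc(N3CCC(N4CCCCC4)CC3)cc1)CC2`: 8.5%

In an assay on HEK293 cells for inhibition of Steryl-sulfatase (Homo sapiens), tested at 0.1 uM (a higher number here means a stronger effect of the compound at the concentration tested, a lower number a weaker effect), compound 1 gives 6.5%. Compound 3 gives 8.5% and compound 2 gives 1.6% in this assay, so all three numbers sit within the usual scatter of one another, and none of the compounds can be called stronger or weaker than another on these data. Each shares the same core carrying the sulfamate and an amide-linked aromatic ring bearing a nitrogen-containing substituent, and each produces only a small effect.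

Compound 4 `NS(=O)(=O)Oc1ccc2c(c1)CN(C(=O)c1cccc(N3CCc4ccccc4C3)c1)CC2` is not yet measured. It differs from compound 1 in one place: 1,2,3,4-tetrahydroisoquinolin-2-yl in place of ethyl((pyridin-2-yl)methyl)amino on an aromatic carbon. Since every measured compound with a nitrogen-bearing substituent on that ring gives a small number in this assay, the expected step from compound 1 to compound 4 is none beyond the scatter, in either direction. Compound 4 is therefore estimated to give 7%, with a range from 0% to 20%, which would mean a step of a number 0.5 percentage points higher from compound 1 to compound 4 (within the scatter).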

Compound 4, a percentage reported as inhibition, at one concentration (the size of the read-out at that concentration, not a potency): 24.1%
The estimate for compound 4 lay 17.1 percentage points below the measured number; measured number above the stated range.
By their numbers in this assay, from the lowest: compounds 2, 1 and 3 (each within the scatter of the next); then compound 4.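

In this assay, the group at this place on the aromatic ring does matter: with 1,2,3,4-tetrahydroisoquinolin-2-yl in place of ethyl((pyridin-2-yl)methyl)amino, the step is a number 17.6 percentage points higher from compound 1 to compound 4 (beyond the scatter). Going by these compounds alone, no earlier pair differed in only one place, and the earlier numbers all lay within the scatter of one another, so this is the first single change that separates two compounds. The two groups carry the same count of heavy atoms, so that count cannot separate them, and nothing measured here accounts for the step.

As far as these compounds go, it remains open whether the step depends on the carbon-only aromatic ring of the entering group or on its non-aromatic ring closed around the nitrogen. A morpholine or an open-chain benzyl(methyl)amino group at this place would help tell these apart.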